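Stereoisomers of a dimethoxyphenyl tetrahydropyran and cytotoxicity

The source may hold more compounds than are shown below. What is called first, only, known or untested is meant among the compounds shown, and "the series" means these compounds.

The compounds are a set of stereoisomers built on one shared core, carrying three dimethoxyphenyl groups, a hydroxyl and an alkenyl chain. Compound 1 `COc1ccc(/C=C/C[C@H]2C[C@H]([C@H](O)c3ccc(OC)c(OC)c3)CO[C@@H]2c2ccc(OC)c(OC)c2)cc1OC` was measured in a functional assay on HL-60 cells (Homo sapiens) for cytotoxicity, read by WST assay, with a stated time of 48 h (a higher number here means a weaker inhibitor, a lower number a stronger inhibitor), and gave 23500 nM, a weak result. Compound 2 `COc1ccc(/C=C/C[C@@H]2C[C@H]([C@H](O)c3ccc(OC)c(OC)c3)CO[C@H]2c2ccc(OC)c(OC)c2)cc1OC` has no single number in this assay, where its entry for compound 2 reads "not determined" (no result reported), although the fact that compounds 1 and 2 differ only in the configuration as drawn makes it a close relative. Compound 3 `COc1ccc(/C=C/C[C@H]2C[C@@H]([C@@H](O)c3ccc(OC)c(OC)c3)CO[C@@H]2c2ccc(OC)c(OC)c2)cc1OC` is the next isomer: the two compounds have the same atoms and bonds and differ only in configuration as drawn: 4 of 5 stereo elements differ; a stereocentre at a saturated ring carbon is drawn R in compound 2 and S in compound 3; a stereocentre at a saturated ring carbon is drawn S in compound 2 and R in compound 3; a stereocentre at a saturated chain carbon is drawn S in compound 2 and R in compound 3; a stereocentre at a saturated ring carbon is drawn R in compound 2 and S in compound 3.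

Compound 2 itself lacks a value in this assay. The change to compound 3 cannot be given a measured size. Within the data shown here, the only anchor is compound 1, whose weak result in this assay suggests that stereochemistry within this set has not produced strong inhibition. A step of no more than the usual scatter, in either direction, is the plainest expectation. Compound 3 is therefore estimated at 25000 nM in this assay, expected to fall between 6000 nM and 100000 nM.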

Compound 3, half-maximal inhibitory concentration: 34700 nM
Beside the measured number, compound 3's estimate is 1.4-fold (0.14 log units) below it; low and high end bracket the measured number.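

Among these compounds, the first measured comparison in this set comes in this assay, with a 1.5-fold higher number from compound 1 to compound 3 (0.17 log units; within the scatter). Changing the drawn configuration at one saturated ring carbon and one saturated chain carbon together therefore leaves the result within the scatter, and nothing but configuration separates the pair: the fact that compounds 1 and 3 differ only in the configuration as drawn. Steps involving compound 2 cannot be read.

The compounds shown leave open what each of these two stereocentres does alone, since a pair changed together could hide two effects that cancel, and what the remaining stereo elements contribute. They also leave open whether an amine in place of the hydroxyl, or a carboxylic acid at the end of the alkenyl chain, would move the number at all.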